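This account rests on a few compounds, and the source may have more. Where it says the series, first, only, none or still open, it means among the compounds named here.

Measured so far:
compound 1, `CCCCCCCCCCCCCCCC(=O)Nc1c(C)cc(C)c2c1OC(C)(C)C2`, 26 nM;
compound 2, `Cc1cc(C)c(NC(=O)C(C)(C)CCCCc2ccccc2)c2c1CC(C)(C)O2`, 210 nM.

In an assay for inhibition of acyl-CoA:cholesterol acyltransferase (Oryctolagus cuniculus), using microsomes (a higher number here means a weaker inhibitor, a lower number a stronger inhibitor), compound 2 gives the higher of the two numbers, and the gap to compound 1, which gives 26 nM, lies beyond the scatter. Compound 3, `Cc1cc(C)c(NC(=O)C(C)(C)CCCc2ccc(CC(C)C)cc2)c2c1CC(C)(C)O2`, has not been measured in this assay. It differs from compound 2 in one place: 4-isobutylphenyl in place of benzyl on a saturated chain carbon, four bonds along the chain from a carbonyl carbon. For the measured compounds named here, no pair of measured compounds differs in this way, so the size of the step cannot be read from a measured pair. Going by the values given here, compound 1, which carries a long saturated chain on the amide and gives the lower number, is the only guide; on that basis a step toward a lower number is expected for compound 3, of moderate size, though a result within the scatter would not surprise. The expected step is a 2.6-fold lower number from compound 2 to compound 3 (0.42 log units; beyond the scatter). For compound 3 the estimate is 80 nM, within the range 25 nM to 250 nM.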

Compound 3, half-maximal inhibitory concentration: 40 nM
Estimate against measurement, compound 3: 2.0-fold (0.30 log units) above, and the stated range covers the measured number.
By their numbers in this assay, from the lowest: compounds 1 and 3 (each within the scatter of the next); then compound 2.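

In this assay, putting 4-isobutylphenyl in place of benzyl on a saturated chain carbon, four bonds along the chain from a carbonyl carbon, gives a 5.3-fold lower number from compound 2 to compound 3 (0.72 log units; beyond the scatter) and lies beyond the scatter. For the compounds shown here, this is the first measured pair to differ at this position, and it shows that the position accepts the larger group, with 10 heavy atoms against 7, and that the number falls rather than rises. No measurement bears on why the number moves in this direction.

The compounds shown leave open whether the isobutyl group itself carries the step, since 4-methylphenyl and 4-tert-butylphenyl do not appear among them. They also leave open how a carboxylic acid or an amine on that aromatic ring would read in this assay.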